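Para-bromo for ortho-fluoro on the ring nitrogen

The source may report more compounds than this note shows. Statements on the series, on what has been measured and on what is new or still open speak of the compounds shown alone.

Of the compounds shown here, three have been measured in a functional assay on NCI-H460 cells (Homo sapiens) for cytotoxicity, read by MTT assay, with a stated time of 72 h; on this read-out higher numbers stand for weaker inhibition and lower numbers for stronger inhibition. Compound 1 `COc1cc2c(Oc3ccc(NC(=O)c4nn(-c5ccc(Br)cc5)c(=O)c5ccccc45)cc3F)ccnc2cc1OCCCN1CCCC1` gives 180 nM. Compound 2 `COc1cc2c(Oc3ccc(NC(=O)c4nn(-c5ccc(F)cc5)c(=O)c5ccccc45)cc3F)ccnc2cc1OCCCN1CCC(C)CC1` gives 110 nM. Compound 3 `COc1cc2c(Oc3ccc(NC(=O)c4nn(-c5ccccc5F)c(=O)c5ccccc45)cc3F)ccnc2cc1OCCCN1CCC(C)CC1` gives 200 nM, the highest of the three numbers, though it lies within the scatter of both of the others. Within the data shown here, the only single-point step among them is a 1.8-fold higher number from compound 2 to compound 3 (0.26 log units; within the scatter).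

Compound 4 `COc1cc2c(Oc3ccc(NC(=O)c4nn(-c5ccc(Br)cc5)c(=O)c5ccccc45)cc3F)ccnc2cc1OCCCN1CCC(C)CC1` differs from compound 3 in one place: 4-bromophenyl in place of 2-fluorophenyl on an aromatic nitrogen. That step has two bearings in the data. The move from the 4-fluorophenyl to the 2-fluorophenyl, a 1.8-fold higher number from compound 2 to compound 3 (0.26 log units; within the scatter), did not leave the scatter. Compound 1 carries the same 4-bromophenyl as compound 4 but a different amine, and its number sits close to that of compound 3. Neither comparison points beyond the scatter, so no step beyond it is expected for compound 4 in this assay, only a modest lean toward a lower number. The step expected for compound 4 is estimated as a 1.5-fold lower number from compound 3 to compound 4 (0.19 log units; within the scatter). Compound 4 is therefore estimated at 130 nM, expected to fall between 60 nM and 280 nM.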

Compound 4, half-maximal inhibitory concentration: 350 nM
Compound 4: middle estimate off by 2.7-fold (0.43 log units), on the low side, outside the stated range (above it).
By their numbers in this assay, from the lowest: compounds 2, 1, 3 and 4 (each within the scatter of the next, the first and the last beyond it).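

In this assay the exchange of 2-fluorophenyl for 4-bromophenyl on the aromatic nitrogen gives a 1.8-fold higher number from compound 3 to compound 4 (0.24 log units; within the scatter) and so does not by itself leave the scatter. Among these compounds, with the 4-methylpiperidin-1-yl amine held fixed, bromo in place of fluoro on the aromatic carbon gives a 3.2-fold higher number from compound 2 to compound 4 (0.50 log units; beyond the scatter) and is the first step here to pass beyond the scatter, showing a modest response to the halogen at this position. With the 4-bromophenyl kept, 4-methylpiperidin-1-yl in place of pyrrolidin-1-yl gives a 1.9-fold higher number from compound 1 to compound 4 (0.29 log units; within the scatter) and adds no step beyond the scatter. No measurement at hand bears on the reason for these steps. Open, on these data alone, is where an unsubstituted phenyl, a 4-chlorophenyl or a 4-methoxyphenyl on the same nitrogen would fall. Also open, as far as these compounds go, is whether the bromo-for-fluoro step holds with pyrrolidin-1-yl as the amine.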